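This account rests on a few compounds, and the source may have more. Where it says the series, first, only, none or still open, it means among the compounds named here.

The compounds here are followed in an ADME assay on microsomes (Homo sapiens) for metabolic stability; on this read-out higher numbers stand for a longer-lived compound and lower numbers for a shorter-lived compound. Compound 1 `O=C(c1cscn1)N1CCC(C(=O)N2N=CC[C@H]2c2ccccc2)CC1` gives > 3 h, which is a limit of the assay and not a number. Compound 2 `CC(C)(C)C(=O)N1N=CCC1c1ccccn1` gives > 1.5 h, and this is also a limit. Compound 3 `O=C(c1cn[nH]c1)N1CCC(C(=O)N2N=CCC2c2ccccc2)CC1` gives > 2.75 h, again a limit, so its true position on this scale is not known as a number.

The next compound is compound 4 `O=C(c1cc[nH]n1)N1CCC(C(=O)N2N=CCC2c2ccccc2)CC1`, and the change from compound 3 is this: 1H-pyrazol-3-yl in place of 1H-pyrazol-4-yl on a carbonyl carbon. In words, 1H-pyrazol-3-yl stands in place of 1H-pyrazol-4-yl on a carbonyl carbon, so the two compounds have the same atoms, joined differently. Among the measured compounds shown here, no pair of measured compounds shows what a change of this kind does in this assay, so no shift beyond the usual scatter is expected, in either direction. The expected step is a step that the limit leaves unreadable from compound 3 to compound 4. Compound 4 is estimated at 3 h, with an expected range from 1.5 h to 6 h.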

Compound 4, half-life: > 2.75 h
Compound 4: no number, only a limit (the forecaster's own chance of this, stated with the estimate: 70%); the middle value lies beyond the limit too.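

No step can be read from compound 3 to compound 4, since each gives only a limit of the assay and not a number: the limit of > 2.75 h in this assay, at which 2 of the 4 values shown sit.

The compounds shown leave open how long either compound really lasts in this assay, and whether 1H-pyrazol-3-yl in place of 1H-pyrazol-4-yl on a carbonyl carbon changes that at all.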